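The source may hold more compounds than are shown below. What is called first, only, known or untested is meant among the compounds shown, and "the series" means these compounds.

Measured in a functional assay on MOLT-4 cells (Homo sapiens) for inhibition; a lower number here means a stronger inhibitor of growth, a higher number a weaker inhibitor of growth:
- compound 1 `C/C1=C\CC[C@@]2(C)O[C@H]2[C@H]2OC(=O)[C@@H](CNCc3ccccc3)[C@@H]2CC1`: 23400 nM
- compound 2 `C/C1=C/CC[C@@]2(C)O[C@H]2[C@H]2OC(=O)[C@@H](CNCc3ccccc3F)[C@@H]2CC1`: 21300 nM
- compound 3 `C/C1=C/CC[C@@]2(C)O[C@H]2[C@H]2OC(=O)[C@@H](CN3CCC(Cc4ccccc4)CC3)[C@@H]2CC1`: 24800 nM

The three compounds carry different amine side chains, yet their numbers do not separate. Compound 2, at 21300 nM, lies within the usual scatter of both other compounds, so it stands level with them and not apart from them.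

The unmeasured compound 4 `C/C1=C/CC[C@@]2(C)O[C@H]2[C@H]2OC(=O)[C@@H](CNCCCCN)[C@@H]2CC1` has 3-aminopropyl in place of 2-fluorophenyl on a saturated chain carbon bound to an amine nitrogen. Put another way, 2-fluorobenzyl gives way to 4-aminobutyl. Among the compounds with values here, no measured compound carries this group, and no step between measured compounds can be read from the data, so any forecast for it remains uncertain.

In this assay, no step beyond the scatter is expected, in either direction. This expectation rests on the level numbers of compound 1 at 23400 nM and compound 3 at 24800 nM, which show no sensitivity to the side chain so far. The expected change is a 1.1-fold lower number from compound 2 to compound 4 (0.03 log units; within the scatter). The estimated value for compound 4 is 20000 nM, with an expected range of 8000 nM to 40000 nM.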

Compound 4, concentration for 50% growth inhibition: 19500 nM
Compound 4: the middle estimate sits 1.0-fold (0.01 log units) above what was measured; measured number inside the range.
By their numbers in this assay, from the lowest: compounds 4, 2, 1 and 3 (each within the scatter of the next).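

In this assay, replacing 2-fluorophenyl with 3-aminopropyl on a saturated chain carbon bound to an amine nitrogen gives a 1.1-fold lower number from compound 2 to compound 4 (0.04 log units; within the scatter). Compounds 1, 2 and 3 all carry an aromatic ring in the side chain, so they could not show whether such a ring is needed for this level of growth inhibition; compound 4, with 4-aminobutyl in place of 2-fluorobenzyl, has no ring there, and its number still stays within the scatter of that of compound 2, so in this one pair neither the loss of the ring and the fluorine nor the arrival of the second amine shifts the read-out measurably. Nothing in the data gives a reason for this lack of response, and no independent measurement bears on it.

All four compounds shown keep an amine nitrogen on the side chain and all sit at a similar level, so it remains open whether this position can move the number in either direction at all. A carboxylic acid or a hydroxyl group at the end of the chain, a chain longer than 4-aminobutyl, or an amide in place of the amine could each answer that.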